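Adding methylsulfanyl to compound 2: expected growth inhibition

The compounds below may be only part of what the source reports. "The series", "measured", "known", "first", "only" and "open" are said of these compounds alone.

The series is followed in an ADME assay on 184B5 cells (Homo sapiens) for cytotoxicity, read by MTT assay, with a stated time of 72 h; on this read-out lower numbers stand for stronger inhibition of growth and higher numbers for weaker inhibition of growth. Among the measured compounds shown here, compound 2 `C[Se]c1nc(NCc2ccccc2)c2ccccc2n1` is the only member with a numerical result, and in this assay compound 2 gives 12400 nM. Compound 1 `CCCCC[Se]c1nc(NCc2ccc(SC)cc2)c2ccccc2n1` carries a pentylselanyl chain and a benzyl group bearing methylsulfanyl. In this assay compound 1 reaches only a limit of the assay, > 100000 nM. For the measured compounds named here, compound 1 and compound 2 differ in more than one place, so no single step connects them; their two values show a number for one and a limit for the other, the limit being (the limit of > 100000 nM in this assay, at which 1 of the 2 values shown sits). Compound 3 `CSc1ccc(CNc2nc([Se]C)nc3ccccc23)cc1` is not yet measured. It differs from compound 2 by methylsulfanyl in place of hydrogen on an aromatic carbon. Going by the values given here, no measured step covers this change, so the expectation rests on compound 2, with compound 1 as the only other member that carries the methylsulfanyl group. The expected step in this assay is a 1.8-fold higher number from compound 2 to compound 3 (0.25 log units; within the scatter), modest and toward weaker inhibition, close to the edge of the scatter. The estimate for compound 3 is 22000 nM, within 6000 nM to 90000 nM, with a real chance that only a limit is reported.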

Compound 3, concentration for total growth inhibition: > 100000 nM
Compound 3 was reported as a limit (the forecaster's own chance of this, stated with the estimate: 25%); at least 4.5-fold (0.65 log units) between middle value and limit.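

In this assay, among the compounds shown here, methylsulfanyl in place of hydrogen on an aromatic carbon, para to a large group, gives an at least 8.0-fold higher number from compound 2 to compound 3 (0.90 log units; beyond the scatter), the first readable step, and it runs toward weaker inhibition of growth. Compound 1 differs from compound 2 in more than one place and could not show this, whereas compound 3 isolates the methylsulfanyl group with the rest of compound 2 unchanged. Compound 1 and compound 3 both stand at a limit and not at a number, so the step between them cannot be read, and nothing can be said about the chain on selenium when methylsulfanyl is present: the limit of > 100000 nM in this assay, at which 2 of the 3 values shown sit.

From the compounds shown here alone, how far the true value of compound 3 lies past its limit remains open, as does the size of any effect of the pentylselanyl chain. Also open, going by these compounds, is whether the shift belongs to methylsulfanyl itself or to any group at this place; a methoxy group, a chlorine atom or an amine there would separate these, and a longer chain on selenium with a plain benzyl group would isolate that change.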